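The source may report more compounds than this note shows. Statements on the series, on what has been measured and on what is new or still open speak of the compounds shown alone.

Measured in a functional assay on cells (Oocyte) for inhibition of Voltage-dependent T-type calcium channel subunit alpha-1H (Homo sapiens), tested at 100 uM; on this read-out higher numbers stand for more inhibition at the one concentration tested (going by the name of the read-out) and lower numbers for less inhibition:
compound 1 `O=C(O)CC1c2ccccc2N=C(N2CCCCC2)N1c1ccccc1` gives 8%
compound 2 `O=C(O)CC1c2ccccc2N=C(N2CCOCC2)N1c1ccccc1` gives 9%
compound 3 `O=C(CC1c2ccccc2N=C(N2CCCCC2)N1c1ccccc1)OCc1ccccc1` gives 15.6%

All three numbers in this assay are small and lie within the usual scatter of one another. The step of a number 1 percentage points higher from compound 1 to compound 2 (within the scatter) follows the exchange of the ring attached to the carbon with a double bond to nitrogen. The step of a number 7.6 percentage points higher from compound 1 to compound 3 (within the scatter) follows the capping of the acid as its benzyl ester. Compound 3 holds the highest of the three numbers, yet its gaps to compound 2 and to compound 1 both fall within the scatter, so no order among the three compounds can be read from these data.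

Compound 4 `O=C(CC1c2ccccc2N=C(N2CCOCC2)N1c1ccccc1)OCc1ccccc1` has not been measured. It differs from compound 3 by morpholin-4-yl in place of piperidin-1-yl on a carbon with a double bond to nitrogen. This is the same kind of change as morpholin-4-yl in place of piperidin-1-yl on a carbon with a double bond to nitrogen, which is made twice among these compounds; the place differs only in that the ring atom two ring bonds away bears a (benzyloxycarbonyl)methyl group rather than a carboxymethyl group (4 heavy atoms). The core of compound 3 differs from the core of compound 1 by benzyl in place of hydrogen on an oxygen next to a carbonyl group.

For compound 4 the step is expected to be a number 0.9 percentage points higher from compound 3 to compound 4 (within the scatter), beside the earlier one, because the same kind of change gave a number 1 percentage points higher from compound 1 to compound 2 (within the scatter). Compound 4 is therefore expected to give about 16.5% in this assay, with an expected range from 5% to 28%. The expectation rests on a single earlier step and on three numbers that all lie within the scatter, so it carries little weight.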

Compound 4, a percentage reported as inhibition, at one concentration (the size of the read-out at that concentration, not a potency): 20.9%
The estimate for compound 4 lay 4.4 percentage points below the measured number, within the range that was stated.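

In this assay, morpholin-4-yl in place of piperidin-1-yl on the benzyl ester core gives a number 5.3 percentage points higher from compound 3 to compound 4 (within the scatter), and this step does not separate from the one on the free acid core: the same change on two cores in this assay, a number 1 percentage points higher (within the scatter) from compound 1 to compound 2 and a number 5.3 percentage points higher (within the scatter) from compound 3 to compound 4, 4.3 percentage points apart, within the scatter of two such steps. Going by these compounds alone, the benzyl ester in place of the acid, with morpholin-4-yl on the carbon with a double bond to nitrogen, gives a number 11.9 percentage points higher from compound 2 to compound 4 (beyond the scatter), the only step in this set printed as beyond the scatter, and it does not separate from its counterpart with piperidin-1-yl: the same change on two cores in this assay, a number 7.6 percentage points higher (within the scatter) from compound 1 to compound 3 and a number 11.9 percentage points higher (beyond the scatter) from compound 2 to compound 4, 4.3 percentage points apart, within the scatter of two such steps. Across these four compounds, each change therefore carries from one core to the other with no measurable difference in step size, but this rests on a single pair of steps per change, and the readings come from a single tested concentration, so they show neither a general rule for the series nor any difference in potency.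

Still open, from the compounds shown here alone, is whether a piperazine ring or an open-chain amine such as dimethylamino on the carbon with a double bond to nitrogen would follow the same steps. Going by these compounds, it is equally open whether a methyl ester or a primary amide in place of the benzyl ester would behave as the benzyl ester does on either core.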